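Hydroxamate series: 4-methylbenzyl replacing propyl on compound 2

A few compounds are considered here, and "the series" means these few. Any claim that something is new, unique, unknown or untested is made for them only; others in the source may bear on it.

Measured so far:
compound 1, `CC(C)(C)c1ccc(CN2CC(=O)N(Cc3ccc(C(=O)NO)cc3)C2=O)cc1`, gives 40.7 nM in an assay on isolated protein for inhibition of protein deacetylase HDAC6 (Homo sapiens), read by fluorescence, with stated times of 10 min and 2 h; on this read-out higher numbers stand for weaker inhibition and lower numbers for stronger inhibition
compound 2, `CCCC1(c2ccccc2)NC(=O)N(Cc2ccc(C(=O)NO)cc2)C1=O`, gives 50.9 nM in this assay

Among the measured compounds shown here, only two compounds carry a number. Compound 2 stands with its value in the scatter of compound 1; the two numbers do not separate, and nothing can be said about which of the two inhibits more strongly. For the measured compounds named here, the two structures also differ in more than one place, so no single step is available between them.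

Compound 3, `Cc1ccc(CC2(c3ccccc3)NC(=O)N(Cc3ccc(C(=O)NO)cc3)C2=O)cc1`, remains to be measured. It differs from compound 2 in one place: 4-methylphenyl in place of ethyl on a saturated chain carbon bound to a saturated ring carbon. Going by the values given here, no measured pair shows this change, so there is no step to lean on. The expectation is for a step from compound 2 to compound 3 that stays within the scatter or reaches at most a modest gain in inhibition, the estimated step being a 1.5-fold lower number from compound 2 to compound 3 (0.16 log units; within the scatter). For compound 3 the estimated value in this assay is 35 nM, with a range from 12 nM to 110 nM.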

Compound 3, half-maximal inhibitory concentration: 82.4 nM
Beside the measured number, compound 3's estimate is 2.4-fold (0.37 log units) below it, within the range that was stated.
By their numbers in this assay, from the lowest: compounds 1, 2 and 3 (each within the scatter of the next, the first and the last beyond it).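

In this assay, 4-methylphenyl in place of ethyl on a saturated chain carbon bound to a saturated ring carbon gives a 1.6-fold higher number from compound 2 to compound 3 (0.21 log units; within the scatter), so compound 2 and compound 3 do not separate. Among the compounds shown here, this is the first single-place reading, and it shows that this position can carry the much larger 4-methylbenzyl, with its added six-membered aromatic ring of carbon only, in place of propyl without a change that stands clear of the scatter. The pair shows no gain in inhibition from the added ring, but a single step within the scatter also fixes no direction for this change, and no measurement is at hand that bears on why the read-out stays where it does.

Going by these compounds, it remains open whether a longer chain such as hexyl, or a chain ending in an amine or a carboxylic acid, would move the number at this place beyond the scatter of compound 2. Also open, on these data alone, is what a plain benzyl, without the methyl group of compound 3, would read here.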